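This account rests on a few compounds, and the source may have more. Where it says the series, first, only, none or still open, it means among the compounds named here.

Compound 3 `Nc1nc(-c2cccc([N+](=O)[O-])c2)nc2sc(CN3CCC(F)CC3)cc12` stands at the edge of an assay on CHO-K1 cells for antagonist activity at adenosine receptor A1 (Homo sapiens), read by a beta-galactosidase reporter, with stated times of 15 min and 6 h; a higher number here means a weaker inhibitor, a lower number a stronger inhibitor: it gives > 10000 nM, which is a limit and not a number, one of three values sitting at the limit of > 10000 nM in this assay, at which 1 of the 3 values shown sits. Compound 1 `Nc1nc(-c2ccco2)nc2sc(CN3CCC(F)CC3)cc12` gives 740 nM in this assay, and compound 2 `N#Cc1ccccc1-c1nc(N)c2cc(CN3CCC(F)CC3)sc2n1` gives 5050 nM. The steps into compound 3 were an at least 13-fold higher number from compound 1 to compound 3 (1.13 log units; beyond the scatter) and an at least 1.9-fold higher number from compound 2 to compound 3 (0.29 log units; that floor lies within the scatter). Compound 4 `COc1cccc(-c2nc(N)c3cc(CN4CCC(F)CC4)sc3n2)c1` differs from compound 3 by methoxy in place of nitro on an aromatic carbon. Among the measured compounds shown here, no measured step exchanges one substituent for another on this phenyl ring; the nearest guide is the small step of an at least 1.9-fold higher number from compound 2 to compound 3 (0.29 log units; that floor lies within the scatter), so for compound 4 a step of an at least 1.6-fold lower number from compound 3 to compound 4 (0.22 log units; that floor lies within the scatter) is expected, back into measurable territory. Compound 4 is estimated at 6000 nM, with a range of 2000 nM to 20000 nM.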

Compound 4, inhibition constant: 3220 nM
The estimate for compound 4 lay 1.9-fold (0.27 log units) above the measured number; the measured number falls inside the stated range.
By their numbers in this assay, from the lowest: compound 1; then compounds 4 and 2 (each within the scatter of the next). At a limit, above all of these: compound 3.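

Compound 3 gives a limit and not a number: the limit of > 10000 nM in this assay, at which 1 of the 4 values shown sits. Methoxy in place of nitro on the aromatic carbon gives a measurable value in this assay, with an at least 3.1-fold lower number from compound 3 to compound 4 (0.49 log units; beyond the scatter), so a substituent at this place on the phenyl ring need not leave a compound at the limit. Among the other groups, a 1.6-fold lower number from compound 2 to compound 4 (0.20 log units; within the scatter) leaves 3-methoxyphenyl level with 2-cyanophenyl, while a 4.4-fold higher number from compound 1 to compound 4 (0.64 log units; beyond the scatter) keeps furan-2-yl the group with the lowest number.

Open, as far as these compounds go, is whether an amine or a hydroxyl on this carbon would bring the number nearer that of compound 1.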